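This account rests on a few compounds, and the source may have more. Where it says the series, first, only, none or still open, it means among the compounds named here.

Of the compounds shown here, three have so far been measured in an assay on HEK293 cells for binding affinity to 5-hydroxytryptamine receptor 7 (Homo sapiens), read by radioligand binding, tested at 1 uM; a higher number here means more inhibition at the concentration tested (going by the name of the read-out), a lower number less inhibition. Compound 1 `CC1CN(CCn2ccc3ccc(Br)cc32)CC(C)N1` gives 26%, compound 2 `CN1CCCN(CCn2ccc3ccc(Br)cc32)CC1` gives 93%, and compound 3 `C=Cc1ccc2ccn(CCN3CCCN(C)CC3)c2c1` gives 79%, the second highest of the three numbers, with compound 2 nearest above it and compound 1 furthest below it. For the measured compounds named here, the only step between compounds differing in one place is a number 14 percentage points lower from compound 2 to compound 3 (beyond the scatter), a modest one. Compound 4 `CN1CCCN(CCn2ccc3ccc(-c4cccnc4)cc32)CC1` differs from compound 3 in a single respect: pyridin-3-yl in place of vinyl on an aromatic carbon. Going by the values given here, no measured step puts pyridin-3-yl in for vinyl, so the bromo-to-vinyl step alone gives a sense of scale, and a further change of similar modest size in either direction seems plausible. A step of a number 9 percentage points lower from compound 3 to compound 4 (within the scatter) is therefore expected, leaning slightly downward. The estimate for compound 4 in this assay is 70%, between 40% and 92%.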

Compound 4, a percentage reported as inhibition, at one concentration (the size of the read-out at that concentration, not a potency): 35%
Compound 4: the middle estimate sits 35 percentage points above what was measured, outside the stated range (below it).
By their numbers in this assay, from the lowest: compounds 1 and 4 (each within the scatter of the next); then compound 3; then compound 2.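

In this assay, the aromatic carbon that carried bromo and vinyl proves sensitive to what sits on it, with a number 44 percentage points lower from compound 3 to compound 4 (beyond the scatter) and a number 58 percentage points lower from compound 2 to compound 4 (beyond the scatter) once pyridin-3-yl enters. The earlier change at this place was much smaller, at a number 14 percentage points lower from compound 2 to compound 3 (beyond the scatter), so the modest effect of that swap does not extend to every group placed here. Nothing available accounts for the loss.

As far as these compounds go, it remains open whether the loss follows the nitrogen of pyridin-3-yl or the aromatic ring itself. A phenyl group at this position would separate the two.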